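The source may report more compounds than this note shows. Statements on the series, on what has been measured and on what is new or still open speak of the compounds shown alone.

In a functional assay on CHO cells for antagonist activity at Orexin/Hypocretin receptor type 1 (Homo sapiens), read by FLIPR (a higher number here means a weaker inhibitor, a lower number a stronger inhibitor), compound 1, `O=C(c1ccc(Cl)c(Cl)c1)N1CCCCC1CCOc1ccc(Cl)c(Cl)c1`, gives 2510 nM. Compound 2, `O=C(NC[C@@H]1CCCCN1C(=O)c1ccccc1-c1ccccc1)c1ccccc1`, gives 7.94 nM in this assay and so stands lowest of the two numbers, well beyond the scatter from compound 1. Compound 3, `O=C(CC[C@@H]1CCCCN1C(=O)c1ccccc1-c1ccccc1)c1ccccc1`, differs from compound 2 by benzoylmethyl in place of benzamido on a saturated chain carbon bound to a saturated ring carbon, the benzamidomethyl becoming a 2-benzoylethyl and the hydrogen-bond donor being lost. Without a measured step of this kind to lean on, the expected change is a modest weakening, a 5.0-fold higher number from compound 2 to compound 3 (0.70 log units; beyond the scatter). Compound 3 is expected to give about 40 nM in this assay, within a range from 10 nM to 200 nM.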

Compound 3, inhibition constant: 10 nM
Estimate against measurement, compound 3: 4.0-fold (0.60 log units) above; the range from low to high includes it.
By their numbers in this assay, from the lowest: compounds 2 and 3 (each within the scatter of the next); then compound 1.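

Putting benzoylmethyl in place of benzamido on a saturated chain carbon bound to a saturated ring carbon gives a 1.3-fold higher number from compound 2 to compound 3 (0.10 log units; within the scatter) in this assay, so the two numbers cannot be told apart. In this pair, then, a low number does not depend on the amide hydrogen, the hydrogen-bond donor that compound 3 lacks. No measurement shown gives a reason for this result. Still open, going by these compounds, is whether the carbonyl itself matters, and what a longer chain or an amine would do at this place.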